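This account rests on a few compounds, and the source may have more. Where it says the series, first, only, none or still open, it means among the compounds named here.

Compound 1 `CS(=O)(=O)c1ccc(C(=O)NCC(=O)N(Cc2ccccc2)Cc2ccccc2)cc1[N+](=O)[O-]`: 1700 nM
Compound 2 `CN(CC(=O)N(Cc1ccccc1)Cc1ccccc1)C(=O)c1ccc(S(C)(=O)=O)c([N+](=O)[O-])c1`: > 60000 nM
Compound 3 `CN(CC(=O)N1CCc2ccccc2C1)C(=O)c1ccc(S(C)(=O)=O)c([N+](=O)[O-])c1`: > 60000 nM

In an assay on isolated protein for inhibition of thyroid hormone receptor alpha (Homo sapiens), read by fluorescence polarization (on this read-out higher numbers stand for weaker inhibition and lower numbers for stronger inhibition), compound 1 gives 1700 nM. For compound 2 the reading in this assay, > 60000 nM, is a limit of the assay and not a number. For compound 3 the reading in this assay, > 60000 nM, is likewise only a limit. Two of the three measured values sit at the limit of > 60000 nM in this assay, at which 2 of the 3 values shown sit. The change from compound 2 to compound 1, (hydrogen in place of methyl on an amide-type nitrogen), gives an at least 35-fold lower number from compound 2 to compound 1 (1.54 log units; beyond the scatter). How the cores of compound 2 and compound 3 differ is not broken down here. Compound 4 `CS(=O)(=O)c1ccc(C(=O)NCC(=O)N2CCc3ccccc3C2)cc1[N+](=O)[O-]` is not yet measured; it arises from compound 3 by the same change, (hydrogen in place of methyl on an amide-type nitrogen), at a place described in the same words. Compound 3 shows only a limit. The true size of the coming step is therefore uncertain. Compound 4 is expected to give 3000 nM in this assay. The step this expectation means is an at least 20-fold lower number from compound 3 to compound 4 (1.30 log units; beyond the scatter), resting on the step seen from compound 2 to compound 1, an at least 35-fold lower number from compound 2 to compound 1 (1.54 log units; beyond the scatter). The expected range for compound 4 runs from 800 nM to 25000 nM.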

Compound 4, half-maximal inhibitory concentration: > 60000 nM
Compound 4: no number, only a limit; the forecaster's own chance of this, stated with the estimate: 20%; middle value at least 20-fold (1.30 log units) away from the limit.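

Compound 3 and compound 4 both give only a limit in this assay, so the step between them cannot be read: the limit of > 60000 nM in this assay, at which 3 of the 4 values shown sit.

The compounds shown leave open whether hydrogen in place of methyl on an amide-type nitrogen changes the reading at all on the core of compound 3.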